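Oxadiazole replaces methoxycarbonyl on the ring amine nitrogen

This account rests on a few compounds, and the source may have more. Where it says the series, first, only, none or still open, it means among the compounds named here.

Compound 1 `COC(=O)N1CCC(Oc2ncnc3c2CCN3c2ccc(S(C)(=O)=O)cc2F)CC1` was run in a functional assay on CHO-K1 cells with Glucose-dependent insulinotropic receptor (Homo sapiens) as the target, read by a luciferase reporter, with a stated time of 5 h (a lower number here means a smaller maximal response, a higher number a larger maximal response), and gives 119%. Of the three numbers in hand this is the second highest. Compound 2 `N#CN1CCC(O)CC1` gives 129% in this assay, a reading within the usual scatter of that for compound 1, so no order between the two can be stated. Compound 3 `CC(C)c1noc(N2CCC(O)CC2)n1` gives 105% in this assay, which is beyond the scatter below compound 1. Compound 3 also carries the 3-isopropyl-1,2,4-oxadiazol-5-yl group that enters in the next compound, though on a different scaffold, so its value is not a step from compound 1.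

Compound 4 `CC(C)c1noc(N2CCC(Oc3ncnc4c3CCN4c3ccc(S(C)(=O)=O)cc3F)CC2)n1` has not been measured. It differs from compound 1 as follows: 3-isopropyl-1,2,4-oxadiazol-5-yl in place of methoxycarbonyl on an amine nitrogen in a ring. Among the compounds with values here, no step between two measured compounds reports this exact exchange on the shared core of compound 1, so any expectation rests on the spread of the three values, all of which lie near or above the reference. The step from compound 1 to compound 4 in this assay is expected to be small, a number 7 percentage points lower from compound 1 to compound 4 (within the scatter), and not clearly beyond the scatter in either direction. Compound 4 is therefore estimated at 112%, with a range from 90% to 135%.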

Compound 4, largest response reached (reported as percent of maximum), in percent of the reference or control that the assay uses: 124%
Compound 4: the middle estimate sits 12 percentage points below what was measured; low and high end bracket the measured number.
By their numbers in this assay, from the lowest: compound 3; then compounds 1, 4 and 2 (each within the scatter of the next).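

Within the data shown here, on the shared core, this assay now gives a first direct reading at the amine nitrogen in a ring: 3-isopropyl-1,2,4-oxadiazol-5-yl in place of methoxycarbonyl amounts to a number 5 percentage points higher from compound 1 to compound 4 (within the scatter). The position therefore accepts a group of 8 heavy atoms with a five-membered aromatic ring in place of one of 4 heavy atoms with no ring, and no order can be stated between the maximal responses of the two compounds. Nothing at hand bears on why these two readings fall within the scatter of each other.

From the compounds shown here alone, this single exchange does not show how much further the group on this nitrogen can vary, so it remains open whether an isopropoxycarbonyl group, a urea or a longer chain would stay within the scatter of compound 1 or move beyond it. Going by these compounds, it also remains open whether the same exchange would give a comparable reading on another core, since only the core of compound 1 carries this step and the largest response alone says nothing about the concentration at which that response is reached.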